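The source may hold more compounds than are shown below. What is called first, only, known or untested is meant among the compounds shown, and "the series" means these compounds.

In a functional assay on MDA-MB-231 cells (Homo sapiens) for antiproliferative activity, read by MTT assay, with a stated time of 24 h (on this read-out higher numbers stand for weaker inhibition and lower numbers for stronger inhibition), compound 1 `CCCCNC(=O)COc1ccc(C(=O)c2c(CCCC)oc3ccccc23)cc1` gives 34500 nM as its read-out. Compound 2 `CCCCc1oc2ccccc2c1C(=O)c1ccc(OCC(=O)N2CCCCC2)cc1` has only a limit, > 50000 nM, and no number. Among the measured compounds shown here, the single measured step, an at least 1.4-fold higher number from compound 1 to compound 2 (0.16 log units; that floor lies within the scatter), concerns the same carbonyl carbon and is the only guide. Compound 3 `CCCCc1oc2ccccc2c1C(=O)c1ccc(OCC(=O)Nc2ccccc2)cc1` carries anilino in place of piperidin-1-yl on a carbonyl carbon. For the measured compounds named here, compound 1 at 34500 nM is the only measured number, so a modest move to a lower number in this assay is expected, possibly none beyond the scatter. The expected change is an at least 1.4-fold lower number from compound 2 to compound 3 (0.15 log units; that floor lies within the scatter) here. For compound 3 the estimated value is 35000 nM, with an expected range of 15000 nM to 70000 nM here.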

Compound 3, half-maximal inhibitory concentration: > 50000 nM
Compound 3 was reported as a limit (the forecaster's own chance of this, stated with the estimate: 35%); at least 1.4-fold (0.15 log units) between middle value and limit.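

In this assay compound 3, with anilino on this carbonyl carbon, is reported as a limit, so the amide hydrogen present in anilino does not by itself give a measured number as butylamino does in compound 1: the limit of > 50000 nM in this assay, at which 2 of the 3 values shown sit. The change of phenyl for butyl on the amide-type nitrogen is an at least 1.4-fold higher number from compound 1 to compound 3 (0.16 log units; that floor lies within the scatter), a floor only. The step between the two limits cannot be read, so anilino and piperidin-1-yl cannot be ranked.

On these data alone, whether a benzylamino group or a longer alkylamino chain on this carbonyl carbon gives a measured number remains open.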